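Phenoxy for propyl on the distal ring of compound 3

The compounds below may be only part of what the source reports. "The series", "measured", "known", "first", "only" and "open" are said of these compounds alone.

Of the compounds shown here, three sharing an amide-linked cyclopropane core have been measured in a functional assay for agonist activity at G protein-coupled receptor 88 (Homo sapiens), read by HTRF and cAMP accumulation; a lower number here means that less compound is needed, a higher number that more compound is needed for the effect. Compound 1 `CN[C@@H](CC(C)C)CN(C(=O)[C@@H]1C[C@H]1c1ccccc1)c1ccc(-c2ccccc2)cc1` gives 2 nM, compound 2 `CC(C)C[C@H](N)CN(C(=O)[C@@H]1C[C@H]1c1ccccc1)c1ccc(-c2cccs2)cc1` gives 1500 nM, and compound 3 `CCCc1ccc(-c2ccc(N(C[C@@H](N)[C@@H](C)CC)C(=O)[C@@H]3C[C@H]3c3ccccc3)cc2)cc1` gives 61 nM. Among these three numbers compound 3 stands second highest: compound 2 sits at a higher number, beyond the scatter, while compound 1 sits at a lower number, also beyond the scatter.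

Compound 4 `CC[C@H](C)[C@H](N)CN(C(=O)[C@@H]1C[C@H]1c1ccccc1)c1ccc(-c2ccc(Oc3ccccc3)cc2)cc1` has not yet been measured in this assay. It differs from compound 3 in one place: phenoxy in place of propyl on an aromatic carbon. No measured pair in this set isolates such a change, so its effect cannot be read from the shown numbers. Compound 1, which carries no substituent on the distal ring of its core, gives the lowest number in this assay, and compound 3 with its propyl group gives a higher one; this does not settle what a phenoxy group will do.

The expectation for compound 4 is a modest step in this assay, of the size a 1.6-fold higher number from compound 3 to compound 4 (0.21 log units; within the scatter), with a higher number somewhat more likely than a lower one. Compound 4 is thus estimated at 100 nM, within a range from 25 nM to 400 nM.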

Compound 4, half-maximal effective concentration: 94 nM
For compound 4 the middle estimate is 1.1-fold (0.03 log units) above the measured one, and the stated range covers the measured number.
By their numbers in this assay, from the lowest: compound 1; then compounds 3 and 4 (each within the scatter of the next); then compound 2.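

In this assay, the exchange of propyl for phenoxy on this aromatic carbon, para to a large group, gives a 1.5-fold higher number from compound 3 to compound 4 (0.19 log units; within the scatter) and leaves compound 3 and compound 4 indistinguishable. Within the data shown here, this is the first direct reading at this position: a substituent that goes from 3 carbon atoms without a ring to 7 heavy atoms with a six-membered aromatic ring and an oxygen produces no change beyond the scatter. Nothing available explains why the two groups give such similar numbers, so this remains an observation about these two compounds alone.

With only propyl and phenoxy compared here, the compounds shown leave open whether this tolerance extends to other kinds of group at the same carbon, such as a carboxylic acid, a primary amine or a chain longer than propyl. They also leave open whether the same exchange would remain within the scatter on compounds that differ from this pair elsewhere, for example in the amine-bearing side chain.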